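A few compounds are considered here, and "the series" means these few. Any claim that something is new, unique, unknown or untested is made for them only; others in the source may bear on it.

Among the measured compounds shown here, compound 2 `O=C(Nc1cccc2c1CCCC2c1c[nH]cn1)C(F)(F)F` gives 661 nM in an assay on isolated protein for binding affinity to Alpha-2B adrenergic receptor (Rattus norvegicus), read by radioligand binding (a higher number here means a weaker inhibitor, a lower number a stronger inhibitor), the lowest of the two numbers so far. For the measured compounds named here, the only other value is that of compound 1 `CCS(=O)(=O)Nc1cccc2c1CCCC2c1c[nH]cn1`, which gives 1700 nM in this assay, the step of a 2.6-fold lower number from compound 1 to compound 2 (0.41 log units; beyond the scatter) being modest. Compound 3 `Nc1cccc2c1CCCC2c1c[nH]cn1` is reached by hydrogen in place of (trifluoromethyl)carbonyl on a nitrogen on an aromatic ring. Going by the values given here, the one measured step bears on this only loosely: it exchanges one substituent on that nitrogen for another, whereas here the substituent is removed altogether. A step of a 2.3-fold higher number from compound 2 to compound 3 (0.36 log units; beyond the scatter) in this assay is therefore expected, with low confidence in its direction. Compound 3 is estimated at 1500 nM, between 400 nM and 6000 nM.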

Compound 3, inhibition constant: 49 nM
Compound 3: the middle estimate sits 31-fold (1.49 log units) above what was measured; the whole stated range lies above it.
By their numbers in this assay, from the lowest: compound 3; then compound 2; then compound 1.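

In this assay, removing the substituent from the nitrogen gives a 13-fold lower number from compound 2 to compound 3 (1.13 log units; beyond the scatter) and a 35-fold lower number from compound 1 to compound 3 (1.54 log units; beyond the scatter). The earlier exchange of one substituent for another showed only a modest difference; the unsubstituted amino compound now gives the lowest number of the three, with either substituent tied to a higher one. Nothing available explains this difference. Still open, going by these compounds, is how a methyl or acetyl group on that nitrogen would read in this assay. Also open, on these data alone, is whether a hydroxyl group could stand in place of the amino group.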